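Thienyl for methoxyphenyl: from compound 2 to compound 3

A few compounds are considered here, and "the series" means these few. Any claim that something is new, unique, unknown or untested is made for them only; others in the source may bear on it.

Two hydroxamic acids have been measured in an assay on Sf9 cells for inhibition of protein deacetylase HDAC6 (Homo sapiens), read by fluorescence, with a stated time of 40 min, tested at 100 nM; a lower number here means less inhibition, a higher number more inhibition at the concentration tested (going by the name of the read-out). Compound 1 `O=C(NO)c1ccc(NCc2nc(-c3cccs3)nn2-c2ccc(O)cc2)cc1` gives 79.6%. Compound 2 `COc1ccc(-c2nc(CNc3ccc(C(=O)NO)cc3)n(-c3ccccc3)n2)cc1` gives 77.6%, which stands as the lower of the two numbers, yet its gap to compound 1 lies within the scatter, so the two are not distinguished. Compound 3 `Cc1ccsc1-c1nc(CNc2ccc(C(=O)NO)cc2)n(-c2ccccc2)n1` has not been measured. It differs from compound 2 in one place: 3-methylthiophen-2-yl in place of 4-methoxyphenyl on an aromatic carbon. For the measured compounds named here, no step between measured compounds is available to size this exchange. A related reading exists, because compound 1, which carries a thiophen-2-yl group at the same place of the shared core, gives 79.6% in this assay. The step from compound 2 to compound 3 is therefore expected to be a number 1.6 percentage points lower from compound 2 to compound 3 (within the scatter), none beyond the scatter. Compound 3 is estimated at 76%, within 62% to 88%.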

Compound 3, a percentage reported as inhibition, at one concentration (the size of the read-out at that concentration, not a potency): 72.1%
Beside the measured number, compound 3's estimate is 3.9 percentage points above it, within the range that was stated.
By their numbers in this assay, from the lowest: compounds 3, 2 and 1 (each within the scatter of the next).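

In this assay, 3-methylthiophen-2-yl in place of 4-methoxyphenyl gives a number 5.5 percentage points lower from compound 2 to compound 3 (within the scatter), the first step read at this position on the aromatic carbon of the five-membered aromatic ring with 3 nitrogen. With the phenyl group on the shared core held constant, a six-membered aromatic ring of carbon only and a five-membered aromatic ring with 1 hetero atom are not distinguished at this position by this read-out. No measurement at hand accounts for the size of this step.

The part played by the methyl group on the thiophene stays unresolved, as compound 1 differs from compound 3 in more than one place. On these data alone, whether this position also accepts a non-aromatic group, such as an amine or a carboxylic acid, remains open.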